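The source may hold more compounds than are shown below. What is called first, only, known or untested is meant among the compounds shown, and "the series" means these compounds.

Measured so far in a functional assay on the whole organism (integument) for inhibition, with Chilo suppressalis as the target, read by scintillation counting, with a stated time of 72 h, in the presence of a further agent that is not named here; on this read-out higher numbers stand for weaker inhibition and lower numbers for stronger inhibition:

Compound 1, `COc1cccc(OC)c1C(=O)Nc1nnc(-c2ccc(Cl)cc2)s1`: 58.9 nM
Compound 2, `COc1cccc(OC)c1C(=O)Nc1nnc(-c2ccc(C(C)C)cc2)s1`: 182 nM
Compound 3, `COc1cccc(OC)c1C(=O)Nc1nnc(-c2ccc(F)cc2)s1`: 89.1 nM

All three compounds share the same core and differ only in the group that sits on the outer phenyl ring. In this assay compound 3 holds the second highest of the three numbers. Its nearest neighbour is compound 1: the step from chloro to fluoro is small, a 1.5-fold higher number from compound 1 to compound 3 (0.18 log units; within the scatter), and lies within the scatter. Against compound 2 the gap is larger, a 2.0-fold lower number from compound 2 to compound 3 (0.31 log units; beyond the scatter), and counts as a modest step beyond the scatter.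

Compound 4, `COc1cccc(OC)c1C(=O)Nc1nnc(-c2ccc([N+](=O)[O-])cc2)s1`, has not yet been measured. It follows from compound 3 by a single change: nitro in place of fluoro on an aromatic carbon. The three measured steps all concern this same position. Swapping one halogen for another moved the number hardly at all, while the step of a 3.1-fold higher number from compound 1 to compound 2 (0.49 log units; beyond the scatter) shows that a bulkier isopropyl gave a modestly higher number. Within the data shown here, a nitro group has no direct precedent here, so the expectation rests on the narrow spread seen across the three measured groups. The step to compound 4 is therefore expected to be small, a 1.1-fold higher number from compound 3 to compound 4 (0.05 log units; within the scatter), most likely not beyond the scatter. On that basis compound 4 is estimated at 100 nM, within a range from 40 nM to 250 nM.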

Compound 4, half-maximal inhibitory concentration: 269 nM
Compound 4: the middle estimate sits 2.7-fold (0.43 log units) below what was measured; the whole stated range lies below it.
By their numbers in this assay, from the lowest: compounds 1 and 3 (each within the scatter of the next); then compounds 2 and 4 (each within the scatter of the next).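

In this assay, the halogens had left this position looking rather flat, but the change from 4-fluorophenyl to 4-nitrophenyl gives a 3.0-fold higher number from compound 3 to compound 4 (0.48 log units; beyond the scatter), and counted from the chloro group it gives a 4.6-fold higher number from compound 1 to compound 4 (0.66 log units; beyond the scatter). So isopropyl is no longer the only group that lifts the number beyond the scatter: nitro, with its hydrogen-bond acceptors where fluoro has none, does not separate from isopropyl, at a 1.5-fold higher number from compound 2 to compound 4 (0.17 log units; within the scatter), and the four compounds fall into two sets, compound 1 with compound 3 at the lower numbers and compound 2 with compound 4 at the higher. Nothing measured here accounts for the rise from fluoro to nitro or for why nitro and isopropyl land together.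

On these data alone, whether isopropyl and nitro share anything that matters here stays open, and other groups at the same place, such as a methoxy, an amine or a carboxylic acid, would be needed to test the two-set picture. Also open, as far as these compounds go, is whether these groups would behave the same way elsewhere on the ring or with a different group on the other side of the shared core.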